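This account rests on a few compounds, and the source may have more. Where it says the series, first, only, none or still open, it means among the compounds named here.

Compound 1 (`O=C(CCCCC1CCSS1)Nc1ccc(OC(F)(F)F)cc1`) has no single number in a functional assay on Bel-7402 cells (Homo sapiens) for inhibition, read by MTT assay, with a stated time of 24 h, tested at 0.1 ug/mL (on this read-out lower numbers stand for less inhibition of growth and higher numbers for more inhibition of growth at the one concentration tested), where compound 1 is simply reported as "not active" (no number reported). Two relatives give some idea of the range in this assay. Compound 2 (`O=C(CCCCC1CCSS1)Nc1cccc2ccccc12`) keeps the same ring on its chain but carries a different group on the amide nitrogen, and compound 2 gives 3.4%. Compound 3 (`O=C(CCCCC(S)CCS)Nc1cccc(Cl)c1`) has an open chain and also a different group on the amide nitrogen, and compound 3 gives 3.09%. These two values lie within the usual scatter of each other, so neither form stands out on these data.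

Compound 4 (`O=C(CCCCC(S)CCS)Nc1ccc(OC(F)(F)F)cc1`) differs from compound 1 in one place: a group of 5 heavy atoms (3 carbon, 2 sulfur; no ring) in place of a group of 5 heavy atoms (3 carbon, 2 sulfur; one five-membered non-aromatic ring with 2 hetero atoms), on a saturated chain carbon, four bonds along the chain from a carbonyl carbon. The ring is opened, leaving the 1,3-disulfanylpropyl group, while the rest of compound 1 stays the same. For the measured compounds named here, no measured pair isolates this change, so its effect cannot be read directly. The open-chain compound 3, at 3.09%, gives no sign of a large gain, so no step beyond the scatter is expected, in either direction. For compound 4 the expected inhibition is 4%, with an estimated range from 0% to 15%.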

Compound 4, percent growth inhibition at one concentration: "not active" (no number reported)
Nothing numeric was reported for compound 4; no gap can be computed for the estimate.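

Compound 1 and compound 4 are both reported without a number in this assay, so no step can be read for opening the ring. Nothing measured here bears on this result. The compounds shown leave open whether ring and open chain differ at all once the trifluoromethoxy-bearing amide gives a measurable value.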